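This account rests on a few compounds, and the source may have more. Where it says the series, first, only, none or still open, it means among the compounds named here.

Measured compounds:
compound 1 `CC1(C)Oc2ccc(C#N)cc2[C@@H](/N=C(\NC#N)NCc2ccccc2)[C@@H]1O` with 2400 nM
compound 2 `COC(=O)c1cc2ccccc2n1[C@@H]1c2cc(C#N)ccc2OC(C)(C)[C@H]1O` with 33100 nM

In a functional assay (aorta) with Rattus norvegicus as the target (on this read-out lower numbers stand for stronger inhibition and higher numbers for weaker inhibition), compound 1 gives 2400 nM, the lowest of the two numbers available. Among the measured compounds shown here, compound 2, the only other measured compound, gives 33100 nM, a number that lies above that of compound 1 by more than the scatter of this assay. For the measured compounds named here, no single-point step between these two measured compounds is defined, so their two values stand on their own.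

The unmeasured compound 3 `CC1(C)Oc2ccc(C#N)cc2[C@@H](/N=C(\NC#N)Nc2cccc(C(=O)O)c2)[C@@H]1O` differs from compound 1 in one place: 3-carboxyphenyl in place of benzyl on an amine nitrogen. The difference, cut one bond further out, reads benzylamino to (3-carboxyphenyl)amino. Going by the values given here, with no measured pair to lean on, the step from compound 1 to compound 3 is expected to be a moderate weakening, a 2.5-fold higher number from compound 1 to compound 3 (0.40 log units; beyond the scatter), somewhat beyond the scatter of this assay. Compound 3 is therefore estimated at 6000 nM, with a range from 1500 nM to 25000 nM.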

Compound 3, half-maximal inhibitory concentration: > 100000 nM
Compound 3: a limit, no number; the forecaster's own chance of this, stated with the estimate: 10%; middle value at least 16-fold (1.22 log units) from the limit.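

In this assay, compound 3 stands at a limit of the assay, > 100000 nM, and not at a number. Placing 3-carboxyphenyl instead of benzyl on this amine nitrogen gives an at least 41-fold higher number from compound 1 to compound 3 (1.61 log units; beyond the scatter), so this position, about which the earlier compounds said nothing, responds strongly to the group it carries. The true size of the step stays open on its upper side: the limit of > 100000 nM in this assay, at which 1 of the 3 values shown sits.

The change both removes the carbon that links the ring to the nitrogen in benzyl and adds a carboxylic acid, and the compounds shown cannot separate these two parts. Open too, on these data alone, is how a plain phenyl or a benzyl carrying the carboxylic acid would read here, and whether an amide or an amine in place of the acid would read differently.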